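A Dichlorophenyl Sulfonamide Replaces the Trifluoromethoxyphenyl Group

The source may report more compounds than this note shows. Statements on the series, on what has been measured and on what is new or still open speak of the compounds shown alone.

Two compounds share a core and differ only in the ring carried on a sulfonyl sulfur. Compound 1 `Cc1c(Cl)ccc(S(=O)(=O)N(C)CCOCC(=O)N(C)Cc2ccc(C3=NCCN3)cc2)c1Cl` carries a 2,4-dichloro-3-methylphenyl group there, and in a functional assay on Umbilical vein for antagonist activity at B1 bradykinin receptor (Homo sapiens), using Schild analysis, with a stated time of 30 min (a lower number here means a less potent compound, a higher number a more potent compound, by a factor of ten per unit of this negative logarithm), compound 1 gives 9.1. Compound 2 `CN(Cc1ccc(C2=NCCN2)cc1)C(=O)COCCN(C)S(=O)(=O)c1ccc(OC(F)(F)F)cc1` carries a 4-(trifluoromethoxy)phenyl group instead, and in this assay compound 2 gives 7.5, the lower of the two numbers; the step of a number 1.60 log units lower from compound 1 to compound 2 (beyond the scatter). Compound 3 `CN(Cc1ccc(C2=NCCN2)cc1)C(=O)COCCN(C)S(=O)(=O)c1c(Cl)cccc1Cl` has not yet been measured. It differs from compound 2 in one place: 2,6-dichlorophenyl in place of 4-(trifluoromethoxy)phenyl on a sulfonyl sulfur. Among the measured compounds shown here, the only step that bears on this change is the one from compound 1 to compound 2, where the ring with chlorines gave the higher number. Compound 3 is therefore expected to recover part of that ground, with an estimated step of a number 0.80 log units higher from compound 2 to compound 3 (beyond the scatter). The value of compound 3 in this assay is estimated at 8.3, within a range from 7.5 to 9.1.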

Compound 3, negative logarithm of the antagonist equilibrium constant: 8.5
For compound 3 the middle estimate is 0.20 log units below the measured one, and the stated range covers the measured number.
By their numbers in this assay, from the lowest: compound 2; then compound 3; then compound 1.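

In this assay, changing the ring on the sulfonyl sulfur to 2,6-dichlorophenyl gives a number 1.00 log units higher from compound 2 to compound 3 (beyond the scatter), so among these three compounds, a ring with chlorines but no methyl group already regains much of the ground lost with 4-(trifluoromethoxy)phenyl. Yet the full 2,4-dichloro-3-methylphenyl group keeps an edge, with a number 0.60 log units lower from compound 1 to compound 3 (beyond the scatter), which shows that having two chlorines on the ring does not settle the number at this position; the rings differ in both the methyl group and where the chlorines sit, and these compounds cannot separate the two. No measurement here explains why these rings give different numbers.

Still open, going by these compounds, is how a plain phenyl ring or a ring with a single chlorine would compare on the same sulfonyl sulfur. Such rings would help show how much of the difference follows the chlorines themselves.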